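The source may report more compounds than this note shows. Statements on the series, on what has been measured and on what is new or still open speak of the compounds shown alone.

Compound 1 `COc1nc2ccc(Br)cc2cc1C(c1ccccc1)n1cc(-c2ccccc2)nn1`: 13.9%
Compound 2 `CCCCCc1cn(C(c2ccccc2)c2cc3cc(Br)ccc3nc2OC)nn1`: -9.81%
Compound 3 `CCCc1cn(C(c2ccccc2)c2cc3cc(Br)ccc3nc2OC)nn1`: -2.25%

In an ADME assay on HeLa cells (Homo sapiens) for cytotoxicity, read by sulforhodamine B assay, with a stated time of 48 h, tested at 10 uM (on this read-out higher numbers stand for more inhibition at the one concentration tested (going by the name of the read-out) and lower numbers for less inhibition), compound 3 stands second highest of the three numbers. Its nearest neighbour is compound 2, with a number 7.6 percentage points higher from compound 2 to compound 3 (within the scatter); the furthest is compound 1, with a number 16.2 percentage points lower from compound 1 to compound 3 (beyond the scatter). Compound 4 `COc1nc2ccc(Br)cc2cc1C(c1ccccc1)n1cc(C2CC2)nn1` differs from compound 3 by cyclopropyl in place of propyl on an aromatic carbon. For the measured compounds named here, none of the measured steps swaps a chain for a ring; the two steps from compound 1, a number 23.7 percentage points lower from compound 1 to compound 2 (beyond the scatter) and a number 16.2 percentage points lower from compound 1 to compound 3 (beyond the scatter), both replace phenyl with an alkyl chain, while the step between the two alkyl chains, a number 7.6 percentage points higher from compound 2 to compound 3 (within the scatter), stays within the scatter. Compound 4 is therefore expected to show no step beyond the scatter, a number 0.8 percentage points lower from compound 3 to compound 4 (within the scatter). The estimate for compound 4 in this assay is -3%, within -15% to 10%.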

Compound 4, a percentage reported as inhibition, at one concentration (the size of the read-out at that concentration, not a potency): -5.84%
Compound 4: middle estimate off by 2.8 percentage points, on the high side; measured number inside the range.
By their numbers in this assay, from the lowest: compounds 2, 4 and 3 (each within the scatter of the next); then compound 1.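

In this assay, a non-aromatic ring of carbon only at this position reads like the open chains, with a number 3.6 percentage points lower from compound 3 to compound 4 (within the scatter) and a number 4 percentage points higher from compound 2 to compound 4 (within the scatter). Only the phenyl of compound 1 stands apart, with a number 19.7 percentage points lower from compound 1 to compound 4 (beyond the scatter), so among these compounds a ring as such does not set phenyl apart from the alkyl groups. Nothing shown gives a reason for this. Open, on these data alone, is whether an amine, a carboxylic acid or a substituted phenyl on this aromatic carbon would give a number that stands apart from those of the alkyl groups.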